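The compounds below may be only part of what the source reports. "The series", "measured", "known", "first", "only" and "open" are said of these compounds alone.

Measured compounds:
compound 1 `CC(C)(C)C(=O)Nc1ccc(-c2cccc(C(=O)N[C@H]3CN[C@@H](C(=O)Nc4ccc(Cl)c(C(F)(F)F)c4)C3)c2)cn1`: 28000 nM
compound 2 `CC(=O)Nc1ccc(-c2cccc(C(=O)N[C@H]3CN[C@@H](C(=O)Nc4ccc(Cl)c(C(F)(F)F)c4)C3)c2)cn1`: 8710 nM
compound 3 `CC(=O)Nc1ccc(-c2ccc(C(=O)N[C@@H](C)C(=O)Nc3ccc(Cl)c(C(F)(F)F)c3)cc2)cn1`: 107000 nM

All three were run in a functional assay on K562 cells (Homo sapiens) for inhibition, read by MTT assay, with a stated time of 48 h; on this read-out higher numbers stand for weaker inhibition and lower numbers for stronger inhibition. Compound 3 gives the highest of the three numbers, 107000 nM, and the difference between its core and the core of compound 2 is not broken down here; their values are simply what they are.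

One change recurs twice in the set. From compound 2 to compound 1 it is tert-butyl in place of methyl on a carbonyl carbon, and it gave a 3.2-fold higher number from compound 2 to compound 1 (0.51 log units; beyond the scatter). Compound 4 `C[C@H](NC(=O)c1ccc(-c2ccc(NC(=O)C(C)(C)C)nc2)cc1)C(=O)Nc1ccc(Cl)c(C(F)(F)F)c1` is not yet measured; it arises from compound 3 by tert-butyl in place of methyl on a carbonyl carbon, at a place described in the same words, so this is the same change on a different core.

Within the data shown here, only the one earlier instance is available, so the expectation for compound 4 rests on compound 1 having given 28000 nM against compound 2 at 8710 nM. The step from compound 3 to compound 4 is expected to be about a 2.8-fold higher number from compound 3 to compound 4 (0.45 log units; beyond the scatter), in the same direction as the earlier one. Compound 4 is thus estimated at 300000 nM in this assay, within 100000 nM to 900000 nM, with a fair chance that only a limit is reported.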

Compound 4, half-maximal inhibitory concentration: 7450 nM
For compound 4 the middle estimate is 40-fold (1.60 log units) above the measured one; measured number below the stated range.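

In this assay, tert-butyl in place of methyl on a carbonyl carbon gives a 14-fold lower number from compound 3 to compound 4 (1.16 log units; beyond the scatter). Set beside the earlier instance, the change has no single direction in this series, and a step read on one core does not transfer to the other: the same change on two cores in this assay, a 3.2-fold higher number (0.51 log units; beyond the scatter) from compound 2 to compound 1 and a 14-fold lower number (1.16 log units; beyond the scatter) from compound 3 to compound 4, 46-fold (1.66 log units) apart, beyond the scatter of two such steps This shows that the outcome of the change depends on the core that carries it, but it does not show which difference between the two cores is responsible, and two pairs give no rule for any further core.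

The compounds shown leave open whether the opposite directions belong to tert-butyl alone or would also appear on both cores with an ethyl, a cyclopropyl or a longer chain on the same carbonyl carbon. Also open, going by these compounds, is how a free amine in place of the acetamido group would read on each core.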